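A few compounds are considered here, and "the series" means these few. Any claim that something is new, unique, unknown or untested is made for them only; others in the source may bear on it.

In a functional assay on cells (Mast cell, Rattus norvegicus) for inhibition, with a stated time of 15 min (a lower number here means that less compound is needed, a higher number that more compound is needed for the effect), three compounds have been examined so far. Compound 1 (`O=C(Cl)c1ccc2occc(=O)c2c1`) yielded no number, its entry reading "nd(insoluble)" (no result reported) and so giving no basis for comparison. Compound 2 (`O=C(Nc1nnn[nH]1)c1cc(=O)c2ccccc2o1`) gives 0.08 ug/mL in this test, and compound 3 (`N#Cc1ccc2oc(C(=O)Nc3nnn[nH]3)cc(=O)c2c1`) gives 2.3 ug/mL and thus holds the higher of the two numbers available. Within the data shown here, the only measured step that bears on what follows is cyano in place of hydrogen on an aromatic carbon, a 29-fold higher number from compound 2 to compound 3 (1.46 log units; beyond the scatter) and so large and beyond the scatter.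

Compound 4 (`Cc1ccc2oc(C(=O)Nc3nnn[nH]3)cc(=O)c2c1`) has methyl in place of cyano on an aromatic carbon, which is counted as methyl in place of cyano on an aromatic carbon in full. Among the measured compounds shown here, no methyl compound has yet been measured, so the size of this step rests on a single comparison. Compound 2, at 0.08 ug/mL with only hydrogen on that carbon, marks how low the number can go once the cyano is absent. Methyl is not hydrogen, however, so only part of that return is assumed. The expected change is a 5.8-fold lower number from compound 3 to compound 4 (0.76 log units; beyond the scatter) in the direction of a lower number, a step likely to lie beyond the scatter. For compound 4 the estimate is 0.4 ug/mL as the expected value, with an expected range from 0.07 ug/mL to 2 ug/mL in this test.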

Compound 4, concentration for half-maximal effect: 0.075 ug/mL
Compound 4: the middle estimate sits 5.3-fold (0.73 log units) above what was measured; low and high end bracket the measured number.
By their numbers in this assay, from the lowest: compounds 4 and 2 (each within the scatter of the next); then compound 3.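

In this assay, replacing the cyano on this aromatic carbon with methyl gives a 31-fold lower number from compound 3 to compound 4 (1.49 log units; beyond the scatter), a change about as large as the earlier one in the opposite direction, a 29-fold higher number from compound 2 to compound 3 (1.46 log units; beyond the scatter). Among these compounds, the comparison with hydrogen gives a 1.1-fold lower number from compound 2 to compound 4 (0.03 log units; within the scatter), so methyl and hydrogen cannot be told apart at this carbon in this test, which the earlier compounds could not show. Among the three groups compared here, therefore, the high number goes with cyano alone and not with the mere presence of a group on this carbon, since methyl, although it also fills the position, leaves the number where hydrogen has it.

The compounds shown leave open whether any other group on this carbon, such as a chlorine, a methoxy, an amine, a carboxylic acid or a longer chain like propyl, would follow methyl or cyano, and whether the same swap would behave alike on the other carbons of that ring. No measurement at hand bears on why cyano and methyl differ so widely at this position.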